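From piperazin-1-yl to (pyrimidin-2-yl)sulfanyl on a shared core

A few compounds are considered here, and "the series" means these few. Any claim that something is new, unique, unknown or untested is made for them only; others in the source may bear on it.

Compound 1 `FC(F)(F)c1ccc(CSc2nc(N3CCNCC3)cc(C(F)(F)F)n2)cc1`: 6210 nM
Compound 2 `FC(F)(F)c1ccc(CSc2nc(N3CCN(c4ccccc4)CC3)cc(C(F)(F)F)n2)cc1`: > 50000 nM (a limit of the assay, not a number)
Compound 3 `FC(F)(F)c1ccc(CSc2nc(N3CCN(c4ncccn4)CC3)cc(C(F)(F)F)n2)cc1`: 18300 nM

In a functional assay on NCI-H1975 cells (Homo sapiens) for inhibition, read by MTT assay, with a stated time of 72 h (on this read-out lower numbers stand for stronger inhibition and higher numbers for weaker inhibition), compound 1 gives 6210 nM, the lowest number of the three, and compound 3 is its nearest neighbour. Compound 4 `FC(F)(F)c1ccc(CSc2nc(Sc3ncccn3)cc(C(F)(F)F)n2)cc1` has not yet been measured. It differs from compound 1 as follows: (pyrimidin-2-yl)sulfanyl in place of piperazin-1-yl on an aromatic carbon. In words, (pyrimidin-2-yl)sulfanyl stands in place of piperazin-1-yl on an aromatic carbon.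

Among the measured compounds shown here, no measured step makes this exact change. The closest guides are the two steps that replace the hydrogen on the ring amine nitrogen of compound 1, a hydrogen that compound 4 also lacks. Pyrimidin-2-yl there gives a 2.9-fold higher number from compound 1 to compound 3 (0.47 log units; beyond the scatter), and phenyl gives an at least 8.0-fold higher number from compound 1 to compound 2 (0.90 log units; beyond the scatter). Both steps go upward, and compound 4 carries the same pyrimidin-2-yl as compound 3, so a modest rise in this assay is expected. The expected step is a 3.2-fold higher number from compound 1 to compound 4 (0.51 log units; beyond the scatter). For compound 4 the estimated value is 20000 nM, with an expected range from 7000 nM to 50000 nM.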

Compound 4, half-maximal inhibitory concentration: 14000 nM
Compound 4: the middle estimate sits 1.4-fold (0.15 log units) above what was measured; measured number inside the range.
By their numbers in this assay, from the lowest: compound 1; then compounds 4 and 3 (each within the scatter of the next). At a limit, above all of these: compound 2.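

In this assay, replacing the whole piperazin-1-yl with (pyrimidin-2-yl)sulfanyl gives a 2.3-fold higher number from compound 1 to compound 4 (0.35 log units; beyond the scatter), a modest step even though the non-aromatic ring and its hydrogen-bond donor are gone. The position therefore still gives a measurable number with no ring amine present, and compound 1 keeps the lowest number of the series. Compound 4 at 14000 nM and compound 3 at 18300 nM lie within the usual scatter of each other, so in this small set, the pyrimidin-2-yl gives similar numbers whether carried on sulfur or on the piperazine ring.

Still open, as far as these compounds go, is whether a morpholin-4-yl ring or a short open-chain amine at this position would give a lower number than compound 1. Nothing measured here explains the upward step from compound 1 to compound 4.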